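The compounds below may be only part of what the source reports. "The series", "measured", "known", "first", "only" and "open" are said of these compounds alone.

Measured so far:
- compound 1, `CCOC(=O)C(=O)Nc1ccc(O)c(=O)cc1`: 10%
- compound 2, `CCOC(=O)C(=O)Nc1ccc(Cl)ccc1=O`: 27%

Both numbers come from a functional assay on the whole organism (strain Sprague-Dawley CD) for inhibition, with Rattus norvegicus as the target, read by paw edema, at a dose of 30 mg/kg by the intraperitoneal route; on this read-out higher numbers stand for a stronger effect at the one dose given and lower numbers for a weaker effect. Compound 2 stands highest of the two, and the nearest number, that of compound 1, lies lower by a gap beyond the scatter. Going by the values given here, no step between compounds that differ in one place is available, so nothing here says how a single change on this core moves the paw edema read-out.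

Compound 3, `CCOC(=O)C(=O)Nc1ccc(NC(=O)C(=O)OCC)c(=O)cc1`, is not yet measured in this assay. It differs from compound 2 as follows: ((ethoxycarbonyl)carbonyl)amino in place of chloro on an aromatic carbon. The entering group is the same ((ethoxycarbonyl)carbonyl)amino that already sits elsewhere on the core, so compound 3 carries two of them.

Among the compounds with values here, with only two numbers and no comparable step, the expectation rests on little. The number for compound 2 is the only anchor, and compound 1 shows that another group at the same place gives a clearly lower number. Compound 3 is therefore estimated at 18%, with a range from 2% to 35%, which means an expected step of a number 9 percentage points lower from compound 2 to compound 3 (within the scatter) that is small and downward, and may well fall within the scatter.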

Compound 3, a percentage reported as inhibition, in the whole organism at one dose (the size of the read-out at that dose, not a potency): 84%
The estimate for compound 3 lay 66 percentage points below the measured number; measured number above the stated range.
By their numbers in this assay, from the lowest: compound 1; then compound 2; then compound 3.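

In this assay, the aromatic carbon three ring bonds from the ring atom that bears a group of 8 heavy atoms proves highly sensitive to what it carries: ((ethoxycarbonyl)carbonyl)amino in place of chloro gives a number 57 percentage points higher from compound 2 to compound 3 (beyond the scatter) on this read-out, and the same group in place of hydroxy gives a number 74 percentage points higher from compound 1 to compound 3 (beyond the scatter) on the same read-out. Both steps point upward and both are large, so the two earlier groups no longer mark the range of this position, and compound 3, which carries two ((ethoxycarbonyl)carbonyl)amino groups, stands highest of the three. No measurement at hand accounts for the size of these steps.

From the compounds shown here alone, it remains open whether the rise needs the complete ((ethoxycarbonyl)carbonyl)amino group at this carbon or only part of it, which a simple amine or a free carboxylic acid there would help to separate. Also open, going by these compounds, is how a longer chain in place of the ethyl end of this group would read, and whether the high number depends on having two such groups rather than one.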